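Plasma stability notes: carboxylic acid replaces the halogenated phenyl

A few compounds are considered here, and "the series" means these few. Any claim that something is new, unique, unknown or untested is made for them only; others in the source may bear on it.

Compound 1 `O=C1c2ccc(OCc3cccc(-c4ccc(Cl)cc4F)c3)cc2CN1C1CCCC1` gives "not determined" (no result reported) in an ADME assay on a cell-free system (plasma, Rattus norvegicus) for metabolic stability, read by LC-MS, with a stated time of 1 h, at 37 degrees C, tested at 100 uM; on this read-out higher numbers stand for a more stable compound and lower numbers for a less stable compound; no number exists for where it stands. Two other members of the series have been measured. In this assay compound 2 `O=C(O)c1cc(F)cc(-c2cccc(COc3ccc4c(c3)CN(C3CCCC3)C4=O)c2)c1` gives 95%. In this assay compound 3 `O=C(O)c1cc(-c2cccc(COc3ccc4c(=O)n(C5CCCC5)sc4c3)c2)cc([N+](=O)[O-])c1` gives 100%; the two values lie within the scatter of each other, so no order can be read between them.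

The step of interest runs from compound 1 to compound 4 `O=C(O)c1ccc(-c2cccc(COc3ccc4c(c3)CN(C3CCCC3)C4=O)c2)c(Cl)c1`. The change is 4-carboxy-2-chlorophenyl in place of 4-chloro-2-fluorophenyl on an aromatic carbon. Going by the values given here, no step between measured compounds that differ in one place is available, so the size of this step cannot be computed from the data. Because compound 2, which also carries a carboxylic acid on the same position of the core, gives 95% in this assay, no step beyond the scatter is expected in either direction, and a high figure is expected for compound 4. Compound 4 is estimated at 95% in this assay, with an expected range from 82% to 100%.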

Compound 4, percent of the compound remaining: 100%
Estimate against measurement, compound 4: 5 percentage points below; the measured number falls inside the stated range.
By their numbers in this assay, from the lowest: compounds 2, 3 and 4 (each within the scatter of the next).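

Among the carboxy-bearing aryl groups on this aromatic carbon, 4-carboxy-2-chlorophenyl in place of 3-carboxy-5-fluorophenyl gives a number 5 percentage points higher from compound 2 to compound 4 (within the scatter) in this assay on the shared core. Going by these compounds alone, this is the first one-place comparison, and it does not separate the two groups, although they differ both in where the carboxy group sits and in which halogen the ring carries. Nothing at hand bears on why the figures for these two groups stand where they do.

Going by these compounds, compound 1 gives "not determined" (no result reported) in this assay, so the step from the 4-chloro-2-fluorophenyl group cannot be read and the part played by the carboxylic acid stays open. Also open, on these data alone, is whether a tetrazole, a primary amide or a methyl ester on the same ring would give a figure like that of the carboxylic acids.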